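The compounds below may be only part of what the source reports. "The series", "measured", "known", "first", "only" and "open" are said of these compounds alone.

Measured so far:
compound 1 `O=C(O)Cc1sc(C(c2ccc(F)cc2)c2ccc(F)cc2)nc1-c1cccc(F)c1`, 1.4 nM
compound 2 `NS(=O)(=O)c1cccc(-c2nc(C(c3ccc(F)cc3)c3ccc(F)cc3)sc2CC(=O)O)c1`, 140 nM
compound 3 `CS(=O)(=O)Nc1cccc(-c2nc(C(c3ccc(F)cc3)c3ccc(F)cc3)sc2CC(=O)O)c1`, 40 nM

In an in vitro assay on HEK385-7 cells for displacement of a labelled ligand from prostaglandin D2 receptor 2 (Homo sapiens) (a higher number here means a weaker inhibitor, a lower number a stronger inhibitor), compound 3 gives the second highest of the three numbers, sitting between compound 1 and compound 2. The step of a 29-fold higher number from compound 1 to compound 3 (1.46 log units; beyond the scatter) is large, and a 3.5-fold lower number from compound 2 to compound 3 (0.54 log units; beyond the scatter) is modest, so the group on this ring matters.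

Compound 4 `O=C(O)Cc1sc(C(c2ccc(F)cc2)c2ccc(F)cc2)nc1-c1ccco1` differs from compound 3 in one place: furan-2-yl in place of 3-(methanesulfonamido)phenyl on an aromatic carbon. For the measured compounds named here, no measured step swaps the ring itself, so the only guide is indirect. The compound without any sulfur-bearing group on that ring, compound 1, carries the lowest number, and both larger groups, a 100-fold higher number from compound 1 to compound 2 (2.00 log units; beyond the scatter) and a 29-fold higher number from compound 1 to compound 3 (1.46 log units; beyond the scatter), raise it. The furan-2-yl is also without such a group, so the expectation for an 8.0-fold lower number from compound 3 to compound 4 (0.90 log units; beyond the scatter) is a clear decrease, though the smaller ring adds uncertainty. Compound 4 is therefore estimated at 5 nM in this assay, with a likely range of 1 nM to 30 nM.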

Compound 4, half-maximal inhibitory concentration: 18 nM
Compound 4: the middle estimate sits 3.6-fold (0.56 log units) below what was measured; the measured number falls inside the stated range.
By their numbers in this assay, from the lowest: compound 1; then compound 4; then compound 3; then compound 2.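

In this assay, furan-2-yl in this position gives a 2.2-fold lower number from compound 3 to compound 4 (0.35 log units; beyond the scatter) and a 7.8-fold lower number from compound 2 to compound 4 (0.89 log units; beyond the scatter), so the smaller five-membered ring, with no sulfur-bearing group, sits below both sulfur-bearing phenyl compounds. Lack of such a group does not by itself restore the number of compound 1, however: a 13-fold higher number from compound 1 to compound 4 (1.11 log units; beyond the scatter) leaves 3-fluorophenyl with the lowest number of the four compounds. No measurement here explains this order among the groups at this position.

Each furan-2-yl step changes the ring and its substituent together, so the separate contribution of ring size, the ring oxygen and the fluoro group remains unresolved. An unsubstituted phenyl would separate the contribution of the fluoro group from that of the ring, and a methyl or an amine on the furan would show whether this smaller ring tolerates substitution.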